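A few compounds are considered here, and "the series" means these few. Any claim that something is new, unique, unknown or untested is made for them only; others in the source may bear on it.

Measured so far:
- compound 1, `C[C@@H](Oc1cc2onc(CCC(=O)O)c2cc1Cl)c1ccc(Cl)cn1`, 3.16 nM
- compound 2, `O=C(O)CCn1c(=O)oc2cc(OCc3ccccn3)c(Cl)cc21`, 3.16 nM
- compound 3, `C[C@@H](Oc1cc2oc(=O)n(CCC(=O)O)c2cc1Cl)c1ccc(Cl)cn1`, 3.16 nM

All three values come from an assay for inhibition of kynurenine 3-monooxygenase (Homo sapiens), read by mass spectrometry, with a stated time of 1 h; on this read-out higher numbers stand for weaker inhibition and lower numbers for stronger inhibition. Compound 2 stands level with compound 1 and compound 3 at the digits shown; the gaps to either of them lie within the scatter, so nothing can be said about order among these three, and none of them can be called the strongest.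

The step under study goes from compound 2 to the not yet measured compound 4, `CCc1cc2oc(=O)n(CCC(=O)O)c2cc1Cl`. The change is ethyl in place of (pyridin-2-yl)methoxy on an aromatic carbon. The group that leaves carries one six-membered aromatic ring with a hetero atom and two hydrogen-bond acceptors; what enters is a short chain with no ring and no acceptor, placed on an aromatic carbon of the shared core, ortho to a chloro group. Among the measured compounds shown here, no measured pair here differs in exactly this way, so the size of the step cannot be read off from the data; it is expected to be a clear weakening, well beyond the scatter, in this assay. Compound 4 is estimated at 150 nM, within a range of 20 nM to 1500 nM, which would be a step of a 47-fold higher number from compound 2 to compound 4 (1.68 log units; beyond the scatter).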

Compound 4, half-maximal inhibitory concentration: 10 nM
For compound 4 the middle estimate is 15-fold (1.18 log units) above the measured one; measured number outside the range, below it.
By their numbers in this assay, from the lowest: compounds 1, 2 and 3 (each within the scatter of the next); then compound 4.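

In this assay, putting ethyl in place of (pyridin-2-yl)methoxy on this aromatic carbon gives a 3.2-fold higher number from compound 2 to compound 4 (0.50 log units; beyond the scatter), a modest weakening that is nevertheless beyond the scatter. The earlier compounds shown here offered no step at this position. This pair shows that ethyl, with no ring and no hydrogen-bond acceptor, can take the place of (pyridin-2-yl)methoxy at a real but limited cost: compound 4 still reaches 10 nM. No measurement shown here explains why the step is this size, so the result describes only the change in inhibition and not its origin.

Going by these compounds, one replacement cannot show whether the outcome is particular to ethyl, so it remains open how a single hydrogen, a methoxy group, an amine or a longer carbon chain such as propyl would fare on the same carbon. The pair also does not separate the share of the pyridine ring from that of the oxygen linking it to the core, a question that a phenylmethoxy or a pyridin-2-ylethyl group could address.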